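Methyl for phenyl on the ring amide nitrogen of compound 3

The source may report more compounds than this note shows. Statements on the series, on what has been measured and on what is new or still open speak of the compounds shown alone.

Measured so far, in a functional assay on the whole organism (Abdomen, strain Swiss albino) with Mus musculus as the target, with stated times of 10 min and 5 min, at a dose of 15 mg/kg by the oral route; on this read-out lower numbers stand for a weaker effect and higher numbers for a stronger effect at the one dose given:
compound 1 `O=C1C2ON=C(c3cn(-c4ccccc4)nc3-c3ccccc3)C2C(=O)N1c1ccccc1`: 30.6%
compound 2 `CN1C(=O)C2ON=C(c3cn(-c4ccccc4)nc3-c3ccccc3)C2C1=O`: 1.17%
compound 3 `O=C1C2ON=C(c3cn(-c4ccccc4)nc3-c3ccc(Br)cc3)C2C(=O)N1c1ccccc1`: 2.75%

Compound 3 stands second highest of the three; its value and that of compound 2 lie within the scatter of each other, while compound 1 stands beyond the scatter higher. The unmeasured compound 4 `CN1C(=O)C2ON=C(c3cn(-c4ccccc4)nc3-c3ccc(Br)cc3)C2C1=O` differs from compound 3 by methyl in place of phenyl on an amide-type nitrogen in a ring. The same change has been seen once: a number 29.4 percentage points lower from compound 1 to compound 2 (beyond the scatter). The step from compound 3 cannot be that large, since a read-out of this kind does not fall below zero; a drop of at most a few points, or none beyond the scatter, is expected: a number 1.8 percentage points lower from compound 3 to compound 4 (within the scatter). Compound 4 is therefore estimated at 1%, within 0% to 8%.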

Compound 4, a percentage reported as activity, at one dose (the size of the read-out at that dose, not a potency): 9.81%
For compound 4 the middle estimate is 8.8 percentage points below the measured one, outside the stated range (above it).
By their numbers in this assay, from the lowest: compounds 2, 3 and 4 (each within the scatter of the next); then compound 1.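

In this assay, methyl in place of phenyl on the ring amide nitrogen has no fixed effect; with the bromo group present, the result is a number 7.1 percentage points higher from compound 3 to compound 4 (within the scatter), and the two cores disagree: the same change on two cores in this assay, a number 29.4 percentage points lower (beyond the scatter) from compound 1 to compound 2 and a number 7.1 percentage points higher (within the scatter) from compound 3 to compound 4, 36.5 percentage points apart, beyond the scatter of two such steps Bromo in place of hydrogen likewise depends on the group on that nitrogen, giving a number 8.6 percentage points higher from compound 2 to compound 4 (within the scatter), and again the cores disagree: the same change on two cores in this assay, a number 27.9 percentage points lower (beyond the scatter) from compound 1 to compound 3 and a number 8.6 percentage points higher (within the scatter) from compound 2 to compound 4, 36.5 percentage points apart, beyond the scatter of two such steps The two changes therefore do not add: once either is in place, the other shows no step beyond the scatter.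

Open, as far as these compounds go, is whether a benzyl group or a longer chain on that nitrogen would behave like phenyl or like methyl. Also open, from the compounds shown here alone, is whether chloro or methoxy in place of bromo would match the bromo step.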